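A few compounds are considered here, and "the series" means these few. Any claim that something is new, unique, unknown or untested is made for them only; others in the source may bear on it.

Working notes on the series.

Compound 1 `Fc1cccc(-c2nc(Nc3ccccc3)c3cc(F)ccc3n2)c1` gives 47600 nM in a functional assay on U2OS cells (Homo sapiens) for cytotoxicity, read by MTT assay, with a stated time of 48 h (a lower number here means a stronger inhibitor, a higher number a weaker inhibitor), the highest of the two numbers here; compound 3 `Nc1ccc(Nc2nc(-c3cccc(F)c3)nc3ccc(F)cc23)cc1` gives 44200 nM, and a 1.1-fold lower number from compound 1 to compound 3 (0.03 log units; within the scatter). Compound 2 `Fc1cccc(-c2nc(Nc3ccccc3F)c3cc(F)ccc3n2)c1` returns only a limit, > 50000 nM, at the top of this assay. That limit is the one noted as the limit of > 50000 nM in this assay, at which 1 of the 3 values shown sits. The move an at least 1.0-fold higher number from compound 1 to compound 2 (0.02 log units; that floor lies within the scatter) and the move an at least 1.1-fold lower number from compound 2 to compound 3 (0.05 log units; that floor lies within the scatter) therefore both stay inside the scatter.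

Compound 4 `Nc1cccc(Nc2nc(-c3cccc(F)c3)nc3ccc(F)cc23)c1` differs from compound 1 by amino in place of hydrogen on an aromatic carbon. Going by the values given here, the one measured step that bears on it is the entry of the same amino group giving compound 3, a 1.1-fold lower number from compound 1 to compound 3 (0.03 log units; within the scatter), which was flat. No step beyond the scatter is expected. Compound 4 is estimated at 45000 nM, range 25000 nM to 50000 nM, implying a 1.1-fold lower number from compound 1 to compound 4 (0.02 log units; within the scatter).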

Compound 4, half-maximal inhibitory concentration: 49700 nM
The estimate for compound 4 lay 1.1-fold (0.04 log units) below the measured number; measured number inside the range.
By their numbers in this assay, from the lowest: compounds 3, 1 and 4 (each within the scatter of the next). At a limit, above all of these: compound 2.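

In this assay, amino in place of hydrogen on an aromatic carbon, meta to a large group, gives a 1.0-fold higher number from compound 1 to compound 4 (0.02 log units; within the scatter). The choice between 3-aminophenyl and 4-aminophenyl also makes no readable difference, with a 1.1-fold higher number from compound 3 to compound 4 (0.05 log units; within the scatter), so the two amino placements are not separated here. The remaining step, a number no higher from compound 2 to compound 4 (the limit leaves the size open), cannot be read. Compound 2 gives only a limit: the limit of > 50000 nM in this assay, at which 1 of the 4 values shown sits.

No readable step among these compounds lies beyond the scatter, so what this ring can tolerate remains undefined. On these data alone, whether a carboxylic acid or a longer aminoalkyl chain in place of amino would move the number stays open.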